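Solubility of a Benzyl Variant Bearing a Dihydroindole

The compounds below may be only part of what the source reports. "The series", "measured", "known", "first", "only" and "open" are said of these compounds alone.

Measured compounds:
- compound 1, `CNC(=O)c1cc(C(=O)NC2CC2)cn(Cc2cccc(OC)c2)c1=O`: 582 ug/mL
- compound 2, `CNC(=O)c1cc(C(=O)NC2CC2)cn(Cc2ccc(F)cc2)c1=O`: 84 ug/mL
- compound 3, `CNC(=O)c1cc(C(=O)NC2CC2)cn(Cc2cccc3cn[nH]c23)c1=O`: 131 ug/mL

In a physicochemical assay for solubility, read by HPLC, in simulated intestinal fluid, with a stated time of 16 h, tested at 125 ug/mL (on this read-out higher numbers stand for higher solubility and lower numbers for lower solubility), compound 1 stands highest of the three; its nearest neighbour is compound 3, its furthest compound 2. Both steps away from it are modest and beyond the scatter: a 6.9-fold lower number from compound 1 to compound 2 (0.84 log units; beyond the scatter) and a 4.4-fold lower number from compound 1 to compound 3 (0.65 log units; beyond the scatter). Compound 2 and compound 3 lie within the scatter of each other, a 1.6-fold higher number from compound 2 to compound 3 (0.19 log units; within the scatter).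

The unmeasured compound 4, `CNC(=O)c1cc(C(=O)NC2CC2)cn(Cc2cccc3c2CCN3)c1=O`, differs from compound 1 in one place: 2,3-dihydro-1H-indol-4-yl in place of 3-methoxyphenyl on a saturated chain carbon bound to an aromatic nitrogen. Going by the values given here, of the measured steps, the one from compound 1 to compound 3 bears most on it, since both the entering group of compound 3 and that of compound 4 add a five-membered ring fused to the six-membered aromatic ring and carry one hydrogen-bond donor. The step to compound 2 shows that removing the 3-methoxyphenyl in favour of another aromatic group also lowered the number. Compound 4 is therefore expected to fall below compound 1 by a modest step, a 3.2-fold lower number from compound 1 to compound 4 (0.51 log units; beyond the scatter). The estimate for compound 4 in this assay is 180 ug/mL, with a range from 70 ug/mL to 450 ug/mL.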

Compound 4, solubility: 100 ug/mL
Compound 4: the middle estimate sits 1.8-fold (0.26 log units) above what was measured; low and high end bracket the measured number.
By their numbers in this assay, from the lowest: compounds 2, 4 and 3 (each within the scatter of the next); then compound 1.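

In this assay, the 2,3-dihydro-1H-indol-4-yl group on a saturated chain carbon bound to an aromatic nitrogen also falls well short of the 3-methoxyphenyl, a 5.8-fold lower number from compound 1 to compound 4 (0.76 log units; beyond the scatter). It cannot be told apart from the other two replacements, a 1.3-fold lower number from compound 3 to compound 4 (0.12 log units; within the scatter) and a 1.2-fold higher number from compound 2 to compound 4 (0.08 log units; within the scatter), so compound 1 stands alone at this position while compound 2, compound 3 and compound 4 form one group. Nothing available here accounts for the separation of compound 1 from the other three.

On these data alone, it remains open whether the number of compound 1 depends on the methoxy group itself or on where it sits, a question that a plain phenyl and a 4-methoxyphenyl would bear on. As far as these compounds go, how a group carrying an amine, such as 3-(aminomethyl)phenyl, would read at this position also remains open.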